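Pentyl on Selenium: What Compound 4 Is Expected to Show

The compounds below may be only part of what the source reports. "The series", "measured", "known", "first", "only" and "open" are said of these compounds alone.

Compound 1, `CCCCC[Se]c1nc(NCc2ccccc2)c2ccccc2n1`, gives 44100 nM in an ADME assay on BEAS-2B cells (Homo sapiens) for cytotoxicity, read by MTT assay, with a stated time of 72 h; a lower number here means a stronger inhibitor of growth, a higher number a weaker inhibitor of growth.
Compound 2, `[SeH]c1nc(NCc2ccccc2)c2ccccc2n1`, gives 3540 nM.
Compound 3, `Nc1nc([SeH])nc2ccccc12`, gives 80 nM.

Compound 3 has the lowest number of the three and is the strongest inhibitor of growth among them; the difference between its core and the core of compound 2 is not broken down here. Compound 2 and compound 1 differ in one place only: pentyl in place of hydrogen on a selenium. That single change made a 12-fold higher number from compound 2 to compound 1 (1.10 log units; beyond the scatter), a large step. Compound 4, `CCCCC[Se]c1nc(N)c2ccccc2n1`, has not been measured yet. It differs from compound 3 by the same kind of change, (pentyl in place of hydrogen on a selenium), at a place that is described in the same words. Because compound 3 gives 80 nM and the same change elsewhere gave a 12-fold higher number from compound 2 to compound 1 (1.10 log units; beyond the scatter), a step of similar size is expected in this assay, so compound 4 is expected to show an 11-fold higher number from compound 3 to compound 4 (1.05 log units; beyond the scatter). The number estimated for compound 4 is 900 nM, expected to fall between 250 nM and 3500 nM.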

Compound 4, concentration for 50% growth inhibition: 52300 nM
Estimate against measurement, compound 4: 58-fold (1.76 log units) below; the whole stated range lies below it.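

Pentyl in place of hydrogen on the selenium gives a 650-fold higher number from compound 3 to compound 4 (2.82 log units; beyond the scatter) in this assay, a large step. Pentyl in place of hydrogen on the selenium gave a higher number on both cores in this assay, but the two steps differ clearly in size, so the size of the step did not carry over from one core to the other: the same change on two cores in this assay, a 12-fold higher number (1.10 log units; beyond the scatter) from compound 2 to compound 1 and a 650-fold higher number (2.82 log units; beyond the scatter) from compound 3 to compound 4, 52-fold (1.72 log units) apart, beyond the scatter of two such steps. With pentyl on the selenium, hydrogen in place of benzyl on a nitrogen on an aromatic ring gives a 1.2-fold higher number from compound 1 to compound 4 (0.07 log units; within the scatter), so compound 1 and compound 4 cannot be told apart in this read-out. The direction of the pentyl step held on these two cores, but two pairs do not explain the gap between the steps and are too few to set a rule for the whole series.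

The compounds shown leave open how a methyl, a longer chain or a chain ending in a carboxylic acid on the selenium would behave on either core. They also leave open whether a methyl in place of benzyl on the nitrogen would change the size of the pentyl step.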